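Chain-extended pyridazinone arylpiperazines: chloro for methoxy

The source may report more compounds than this note shows. Statements on the series, on what has been measured and on what is new or still open speak of the compounds shown alone.

Measured so far in an assay on cell membranes from brain for binding affinity to Adrenergic receptor alpha-1 (Rattus norvegicus), read by radioligand binding; on this read-out lower numbers stand for stronger inhibition and higher numbers for weaker inhibition:
compound 1 `COc1ccccc1N1CCN(CCCn2nc(-n3cnc4ccccc43)ccc2=O)CC1`, 6.5 nM
compound 2 `COc1ccccc1N1CCN(CCCCCn2nc(-n3cnc4ccccc43)ccc2=O)CC1`, 3.1 nM
compound 3 `O=c1ccc(-n2cnc3ccccc32)nn1CCCCN1CCN(c2ccccc2Cl)CC1`, 1.3 nM

Compound 2 stands second highest of the three numbers in this assay. Its nearest neighbour is compound 1, whose number is higher and lies beyond the scatter; compound 3 gives the lowest number of the set, below compound 2 by a margin also beyond the scatter. Compound 3 carries both a chloro group and a shorter chain than compound 2, so the two values alone cannot say which of the two changes carries the difference.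

Compound 4 `O=c1ccc(-n2cnc3ccccc32)nn1CCCCCN1CCN(c2ccccc2Cl)CC1` is not yet measured. It differs from compound 2 in one place: chloro in place of methoxy on an aromatic carbon. The remaining structure, including the five-carbon chain, is kept.

For the measured compounds named here, with no single-point step between measured compounds available, the expectation rests on compound 3 giving 1.3 nM with the same chloro group. The step from compound 2 to compound 4 is expected to be a 1.9-fold lower number from compound 2 to compound 4 (0.29 log units; within the scatter), a modest decrease that may sit near the edge of the scatter. Compound 4 is estimated at 1.6 nM, with a range from 0.6 nM to 4.5 nM.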

Compound 4, inhibition constant: 4.5 nM
The estimate for compound 4 lay 2.8-fold (0.45 log units) below the measured number; low and high end bracket the measured number.
By their numbers in this assay, from the lowest: compound 3; then compounds 2, 4 and 1 (each within the scatter of the next, the first and the last beyond it).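

With the chain and the shared core kept, replacing 2-methoxyphenyl by 2-chlorophenyl in this assay gives a 1.5-fold higher number from compound 2 to compound 4 (0.16 log units; within the scatter) and so does not separate the two groups at this place, on an aromatic carbon ortho to a large group. For the compounds shown here, this is the first comparison that isolates the substituent, and methoxy and chloro read alike here despite their different counts of heavy atoms and hydrogen-bond acceptors. Chloro alone therefore does not reproduce the low number of compound 3: with chloro on both, compound 3 gives 1.3 nM and compound 4 gives 4.5 nM in this assay and the two differ only in the chain.

Still open, from the compounds shown here alone, is whether fluoro, methyl, ethoxy or plain hydrogen at this place would read apart from methoxy and chloro, and whether a longer chain carrying 2-chlorophenyl would hold the number of compound 4 or move from it. No measurement at hand accounts for why the two groups read alike or for what the chain contributes.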